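Trimming an Acetyl Group to a Methyl

This account rests on a few compounds, and the source may have more. Where it says the series, first, only, none or still open, it means among the compounds named here.

Measured so far:
Compound 1, `CN(C)CC(=O)N1CCC(NS(=O)(=O)c2cc(S(=O)(=O)c3ccccc3)ccc2C(F)(F)F)CC1`: 280 nM
Compound 2, `CC(=O)N1CCC[C@H]1C(=O)N1CCC(NS(=O)(=O)c2cc(S(=O)(=O)c3ccccc3)ccc2C(F)(F)F)CC1`: 250 nM

In a functional assay on U2OS cells for antagonist activity at proto-oncogene Wnt-3 (Homo sapiens), read by a luciferase reporter, with a stated time of 18 h (a lower number here means that less compound is needed, a higher number that more compound is needed for the effect), compound 1 gives 280 nM, and compound 2 gives 250 nM. The two numbers sit within the scatter of each other, as the step of a 1.1-fold lower number from compound 1 to compound 2 (0.05 log units; within the scatter) shows, so neither compound can be set apart from the other on these numbers.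

Compound 3, `CN1CCC[C@H]1C(=O)N1CCC(NS(=O)(=O)c2cc(S(=O)(=O)c3ccccc3)ccc2C(F)(F)F)CC1`, keeps the shared core of compound 2 and alters only the group on the ring nitrogen: methyl in place of acetyl on an amine nitrogen in a ring.

Within the data shown here, the one measured step, a 1.1-fold lower number from compound 1 to compound 2 (0.05 log units; within the scatter), exchanged the whole group on the carbonyl carbon and produced no change beyond the scatter. It touches the same region of the molecule but not the same bond, so it gives only weak guidance. With the ring and the carbonyl of compound 2 retained, and nothing measured that speaks against it, compound 3 is expected to give a number close to that of compound 2, with the step of a 1.2-fold higher number from compound 2 to compound 3 (0.08 log units; within the scatter) expected to stay within the scatter. The estimate for compound 3 in this assay is 300 nM, with a range from 120 nM to 800 nM.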

Compound 3, half-maximal effective concentration: 230 nM
The estimate for compound 3 lay 1.3-fold (0.12 log units) above the measured number; the range from low to high includes it.
By their numbers in this assay, from the lowest: compounds 3, 2 and 1 (each within the scatter of the next).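

In this assay, among these compounds, putting methyl in place of acetyl on the amine nitrogen in the ring gives a 1.1-fold lower number from compound 2 to compound 3 (0.04 log units; within the scatter), so this is the first look at the ring nitrogen itself: the group there can lose its carbonyl and its hydrogen-bond acceptor while the numbers stay within the scatter of each other. The wider exchange of the whole group on the carbonyl carbon gives a 1.2-fold lower number from compound 1 to compound 3 (0.09 log units; within the scatter), so all three compounds now stand within the scatter and none can be set apart from the others. Nothing measured here offers an explanation for this result.

Only acetyl and methyl are shown on this nitrogen, which leaves open how the number would respond to a plain hydrogen there, a longer chain such as propyl, or a group carrying a carboxylic acid. Also open, as far as these compounds go, is whether any group at this place can move the number beyond the scatter, in either direction.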